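This account rests on a few compounds, and the source may have more. Where it says the series, first, only, none or still open, it means among the compounds named here.

Compound 3 `CN(C)c1ccc(-c2cccc(NC(=O)C(C)(C)C)c2)cc1` stands at the edge of what an assay on COS-7 cells for inhibition of patatin-like phospholipase domain-containing protein 2 (Mus musculus) (on this read-out higher numbers stand for weaker inhibition and lower numbers for stronger inhibition), can report: its value of > 200000 nM is a limit, not a number. Compound 1 `CN(C)c1ccc(-c2cccc([N+](=O)[O-])c2)cc1` also returns only a limit, > 200000 nM. Compound 2 `CCOC(=O)Nc1cccc(-c2ccc(N(C)C)cc2)c1` gives 3000 nM in this assay, and the limit of > 200000 nM in this assay, at which 2 of the 3 values shown sit, marks where the other two sit. Compound 4 `CCOC(=O)N(C)c1cccc(-c2ccc(N(C)C)cc2)c1` differs from compound 3 by (ethoxycarbonyl)(methyl)amino in place of ((tert-butyl)carbonyl)amino on an aromatic carbon. The step of an at least 66-fold higher number from compound 2 to compound 3 (1.82 log units; beyond the scatter) bears directly on this, as compound 4 carries the ethoxycarbonyl group back; the step of an at least 66-fold lower number from compound 1 to compound 2 (1.82 log units; beyond the scatter) also shows how strongly the carbamate matters. A large fall is therefore expected, an at least 20-fold lower number from compound 3 to compound 4 (1.30 log units; beyond the scatter), tempered by the methyl on the nitrogen. Compound 4 is estimated at 10000 nM, between 2000 nM and 100000 nM.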

Compound 4, half-maximal inhibitory concentration: > 200000 nM
Compound 4: no number, only a limit; the forecaster's own chance of this, stated with the estimate: 20%; middle value at least 20-fold (1.30 log units) away from the limit.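

Methyl in place of hydrogen on the amide-type nitrogen gives an at least 66-fold higher number from compound 2 to compound 4 (1.82 log units; beyond the scatter), so the ethoxycarbonyl group alone does not preserve the inhibition seen with compound 2. In this assay, compound 4 returns only a limit, not a number: the limit of > 200000 nM in this assay, at which 3 of the 4 values shown sit. The steps to compound 4 from compound 1 and from compound 3 cannot be read, since both ends are limits.

The compounds shown leave open whether a longer chain such as butoxy in place of ethoxy, or a urea in place of the carbamate, retains inhibition while the nitrogen keeps its hydrogen.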